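The compounds below may be only part of what the source reports. "The series", "measured", "known", "first", "only" and "open" are said of these compounds alone.

Compound 1 `CCn1c(C(=O)Nc2ccc(OC(F)(F)F)cc2)ccc1C(CC)(CC)c1ccc(OCCC(O)(CC)CC)c(C)c1`: > 10000 nM
Compound 2 `CCn1c(C(=O)Nc2cccc(C(F)(F)F)c2)ccc1C(CC)(CC)c1ccc(OCCC(O)(CC)CC)c(C)c1`: 5900 nM
Compound 3 `CCOC(=O)CN(C)C(=O)c1ccc(C(CC)(CC)c2ccc(OCCC(O)(CC)CC)c(C)c2)n1CC`: 520 nM

In an assay on cells for agonist activity at vitamin D3 receptor (Homo sapiens), with a stated time of 96 h (a higher number here means that more compound is needed for the effect, a lower number that less compound is needed), compound 3 gives 520 nM, the lowest of the two numbers measured, while compound 2 gives 5900 nM. Compound 1 gives > 10000 nM, which is a limit of this assay and not a number (the limit of > 10000 nM in this assay, at which 1 of the 3 values shown sits). The unmeasured compound 4 `CCOC(=O)C(CC(=O)OC)NC(=O)c1ccc(C(CC)(CC)c2ccc(OCCC(O)(CC)CC)c(C)c2)n1CC` differs from compound 3 by a group of 12 heavy atoms (7 carbon, 1 nitrogen, 4 oxygen; no ring) in place of a group of 8 heavy atoms (5 carbon, 1 nitrogen, 2 oxygen; no ring), on a carbonyl carbon. Among the measured compounds shown here, two measured steps touch the same carbonyl carbon: an at least 19-fold lower number from compound 1 to compound 3 (1.28 log units; beyond the scatter) and an 11-fold lower number from compound 2 to compound 3 (1.05 log units; beyond the scatter). In both, an aryl amine gave way to an ester-bearing amino group, and the number fell sharply. Compound 4 keeps an ester-bearing amino group at that carbon. The expected step is therefore small, within the scatter: a 1.0-fold lower number from compound 3 to compound 4 (0.02 log units; within the scatter). Compound 4 is expected to give about 500 nM, in a range from 150 nM to 1700 nM.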

Compound 4, half-maximal effective concentration: 21 nM
Compound 4: the middle estimate sits 24-fold (1.38 log units) above what was measured; the whole stated range lies above it.
By their numbers in this assay, from the lowest: compound 4; then compound 3; then compound 2. At a limit, above all of these: compound 1.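

Keeping an ester on the amino group at this carbonyl carbon did not settle the position: the larger group brings a 25-fold lower number from compound 3 to compound 4 (1.39 log units; beyond the scatter) and so still moves the number a great deal. Against the aryl amides the gap is wider still, with a 280-fold lower number from compound 2 to compound 4 (2.45 log units; beyond the scatter) and an at least 470-fold lower number from compound 1 to compound 4 (2.67 log units; beyond the scatter) on top of that. The last of these is only a floor, as compound 1 sits at a limit and not a number: the limit of > 10000 nM in this assay, at which 1 of the 4 values shown sits.

The entering group differs in several ways at once, so the second ester, the amide hydrogen and the longer chain cannot be told apart here. From the compounds shown here alone, what a carboxylic acid in place of either ester would give stays open.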